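A Fluorinated Indazole in Place of a Methylated One

The source may report more compounds than this note shows. Statements on the series, on what has been measured and on what is new or still open speak of the compounds shown alone.

Measured in a functional assay on MCF7 cells (Homo sapiens) for cytotoxicity, read by CellTiter-Glo, with a stated time of 5 days (a lower number here means a stronger inhibitor, a higher number a weaker inhibitor), so far:
compound 1, `COC/C(=C(/c1ccc(/C=C/C(=O)O)cc1)c1ccc2[nH]ncc2c1)c1ccccc1`: 88 nM
compound 2, `O=C(O)/C=C/c1ccc(/C(=C(\c2ccccc2)C2CCCC2)c2ccc3[nH]ncc3c2)cc1`: 10 nM
compound 3, `CC/C(=C(/c1ccc(/C=C/C(=O)O)cc1)c1ccc2[nH]nc(C)c2c1)c1ccccc1`: > 1000 nM

Going by the values given here, compound 3 gives only a limit in this assay, > 1000 nM, so no number is known for it; it is the one value sitting at the limit of > 1000 nM in this assay, at which 1 of the 3 values shown sits. Compound 4, `CC/C(=C(/c1ccc(/C=C/C(=O)O)cc1)c1cc2cn[nH]c2cc1F)c1ccccc1`, differs from compound 3 by a single change: 6-fluoro-1H-indazol-5-yl in place of 3-methyl-1H-indazol-5-yl on a double-bonded chain carbon bound to an aromatic carbon and a double-bonded chain carbon. Among the compounds with values here, the only measured step, an 8.8-fold lower number from compound 1 to compound 2 (0.94 log units; beyond the scatter), alters a different place on the shared core, so no measured step bears directly on the new change. Compound 4 is therefore expected to give about 300 nM in this assay, within a wide range from 30 nM to 3000 nM. That estimate would mean a step of an at least 3.3-fold lower number from compound 3 to compound 4 (0.52 log units; beyond the scatter) from the limit of compound 3.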

Compound 4, half-maximal inhibitory concentration: 47 nM
Beside the measured number, compound 4's estimate is 6.4-fold (0.81 log units) above it; the range from low to high includes it.
By their numbers in this assay, from the lowest: compound 2; then compounds 4 and 1 (each within the scatter of the next). At a limit, above all of these: compound 3.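

Putting 6-fluoro-1H-indazol-5-yl in place of 3-methyl-1H-indazol-5-yl gives an at least 21-fold lower number from compound 3 to compound 4 (1.32 log units; beyond the scatter) in this assay. Going by these compounds alone, the only earlier step, an 8.8-fold lower number from compound 1 to compound 2 (0.94 log units; beyond the scatter), changed a different place, so this is the first sign that the number also responds strongly to the group at this place. The entry for compound 3 is a limit, not a number, so the true size of the step stays unknown: the limit of > 1000 nM in this assay, at which 1 of the 4 values shown sits.

The swap removes a methyl and adds a fluorine at once, so the compounds shown cannot tell which of the two carries the step. On these data alone, how a chlorine or a nitrile in the place of that fluorine would read also stays open.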